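Aryl trithiocarbonate ketones: swapping chloro for methanesulfonamido

The source may report more compounds than this note shows. Statements on the series, on what has been measured and on what is new or still open speak of the compounds shown alone.

Of the compounds shown here, three of the shared core have been measured in a functional assay on HeLa cells (Homo sapiens) for antiproliferative activity, read by resazurin assay; on this read-out lower numbers stand for stronger inhibition and higher numbers for weaker inhibition. Compound 1 `CCSC(=S)SCC(=O)c1ccc(Cl)c(Cl)c1` gives 7940 nM in this assay. Compound 2 `CCSC(=S)SCC(=O)c1ccc(Cl)cc1` gives 5010 nM, and compound 3 `CCSC(=S)SCC(=O)c1ccccc1OC` gives 15800 nM. Compound 2 thus gives the lowest of the three numbers, but its gap to compound 1 is within the scatter; only compound 3 stands clearly apart from it. Going by the values given here, the one single-point step measured so far, a 1.6-fold lower number from compound 1 to compound 2 (0.20 log units; within the scatter), is within the scatter, so removing one chloro on the aromatic ring did not shift the read-out in a meaningful way.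

Compound 4 `CCSC(=S)SCC(=O)c1ccc(NS(C)(=O)=O)cc1` is not yet measured. It differs from compound 2 by methanesulfonamido in place of chloro on an aromatic carbon. Among the compounds with values here, no measured pair in the set shows a chloro traded for a methanesulfonamido, or any group with hydrogen-bond donors entering the aromatic ring, so the only step that bears on it, the loss of a chloro from compound 1 to compound 2, is small and indirect. The replacement is larger than that step, and the expectation for compound 4 is therefore a somewhat higher number than compound 2, with wide uncertainty: the step expected is a 2.0-fold higher number from compound 2 to compound 4 (0.30 log units; within the scatter). Compound 4 is estimated at 10000 nM, with a range from 3000 nM to 40000 nM in this assay.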

Compound 4, half-maximal inhibitory concentration: 39800 nM
Compound 4: middle estimate off by 4.0-fold (0.60 log units), on the low side, and the stated range covers the measured number.
By their numbers in this assay, from the lowest: compounds 2, 1 and 3 (each within the scatter of the next, the first and the last beyond it); then compound 4.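

Going by these compounds alone, replacing the chloro with methanesulfonamido on the aromatic carbon para to a group of 9 heavy atoms gives a 7.9-fold higher number from compound 2 to compound 4 (0.90 log units; beyond the scatter) in this assay and, unlike the only earlier step, a 1.6-fold lower number from compound 1 to compound 2 (0.20 log units; within the scatter), this one lies beyond the scatter. The read-out in this series therefore does respond to a ring substituent, and at this position the change from chloro to methanesulfonamido moves it towards weaker inhibition. The change alters several counted features at once, with 5 heavy atoms entering for 1 and 1 hydrogen-bond donor and 2 hydrogen-bond acceptors entering where the chloro has none, and no measurement available accounts for the step.

The compounds shown leave open which of these differences tracks with the higher number, and a methyl on the nitrogen of the methanesulfonamido, an acetamido group or a simple amine at the same position would begin to separate them. From the compounds shown here alone, it also remains open whether a carboxylic acid or a methoxy group at this position would follow methanesulfonamido or stay within the scatter of chloro.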